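From a small amine ether to a larger side chain

This account rests on a few compounds, and the source may have more. Where it says the series, first, only, none or still open, it means among the compounds named here.

In an ADME assay on microsomes from liver (Homo sapiens) for metabolic stability, read by LC-MS, tested at 1 uM (a lower number here means slower removal, a higher number faster removal of the compound), compound 3 (`NCCOc1ccc([C@H]2CC[C@]3(CC2)OOC2(O3)C3CC4CC(C3)CC2C4)cc1`) gives < 7 mL.min-1.g-1 as its reading, which is a limit of the assay and not a number. Its place in the set is known only that far (the limit of < 7 mL.min-1.g-1 in this assay, at which 1 of the 3 values shown sits). Compound 1 (`O=S(=O)(c1ccc([C@H]2CC[C@]3(CC2)OOC2(O3)C3CC4CC(C3)CC2C4)cc1)N1CCNCC1`) gives 16 mL.min-1.g-1 in this assay and compound 2 (`c1cc([C@H]2CC[C@]3(CC2)OOC2(O3)C3CC4CC(C3)CC2C4)ccc1OCCCNC1CCOCC1`) gives 10 mL.min-1.g-1 there, with the two joined by a step inside the scatter (a 1.6-fold lower number from compound 1 to compound 2 (0.20 log units; within the scatter)).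

Compound 4 (`CC(C)(O)CN1CCC(Oc2ccc([C@H]3CC[C@]4(CC3)OOC3(O4)C4CC5CC(C4)CC3C5)cc2)CC1`) keeps the shared core and alters one group (1-(2-hydroxy-2-methylpropyl)piperidin-4-yl in place of 2-aminoethyl on an oxygen on an aromatic ring). Here 1-(2-hydroxy-2-methylpropyl)piperidin-4-yl stands in place of 2-aminoethyl on an oxygen on an aromatic ring.

Among the compounds with values here, the closest measured change is the one linking compound 2 with compound 3 (an at least 1.4-fold lower number from compound 2 to compound 3 (0.15 log units; that floor lies within the scatter)), whose floor lies within the scatter. Read backwards, it offers a modest rise at most as the group on that oxygen grows. The step from the sulfonyl compound (an at least 2.2-fold lower number from compound 1 to compound 3 (0.35 log units; beyond the scatter)) exchanges a different group and bears less directly.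

A small upward move is therefore expected, and it may not clear the scatter (an at least 1.4-fold higher number from compound 3 to compound 4 (0.15 log units; that floor lies within the scatter)). For compound 4 the estimated value is 10 mL.min-1.g-1 in this assay with an expected range from 5 mL.min-1.g-1 to 20 mL.min-1.g-1 around it.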

Compound 4, intrinsic clearance in microsomes: 18 mL.min-1.g-1
Compound 4: the middle estimate sits 1.8-fold (0.26 log units) below what was measured, and the stated range covers the measured number.
By their numbers in this assay, from the lowest: compounds 2, 1 and 4 (each within the scatter of the next). At a limit, below all of these: compound 3.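

In this assay, within the data shown here, 1-(2-hydroxy-2-methylpropyl)piperidin-4-yl in place of 2-aminoethyl on an oxygen on an aromatic ring gives the first step between groups on this oxygen that is printed as beyond the scatter (an at least 2.5-fold higher number from compound 3 to compound 4 (0.41 log units; beyond the scatter)), so the earlier hint of a rise with a larger group, whose floor lay within the scatter, now has firmer support from this pair. The two larger groups on this oxygen are not separated from each other (a 1.8-fold higher number from compound 2 to compound 4 (0.26 log units; within the scatter)), and the sulfonyl compound, which carries its group directly on an aromatic carbon, also stays within the scatter of the new compound (a 1.1-fold higher number from compound 1 to compound 4 (0.05 log units; within the scatter)). The reading for compound 3 remains a limit of the assay and not a number, so the step from it is a floor and its full size is unknown: the limit of < 7 mL.min-1.g-1 in this assay, at which 1 of the 4 values shown sits.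

The compounds shown do not separate what the piperidin-4-yl ring contributes from what the 2-hydroxy-2-methylpropyl contributes. As far as these compounds go, a plain piperidin-4-yl on the same oxygen would bear on that question, and how a carboxylic acid on this side chain would read remains open.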